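A few compounds are considered here, and "the series" means these few. Any claim that something is new, unique, unknown or untested is made for them only; others in the source may bear on it.

Series notes. Compound 1 `S=C(Nc1ccccc1)N1N=C(c2ccccc2)CC1c1ccc2c(c1)OCCO2` gives 57600 nM in a functional assay on HCT-116 cells (Homo sapiens) for antiproliferative activity, read by MTT assay, with a stated time of 48 h (a lower number here means a stronger inhibitor of growth, a higher number a weaker inhibitor of growth), the lowest of the two numbers at hand. Compound 3 `CSc1ccc(C2=NN(C(=S)Nc3ccccc3)C(c3ccc4c(c3)OCCO4)C2)cc1` gives 193000 nM in this assay. For compound 2 `S=C(Nc1ccccc1)N1N=C(c2ccc(Cl)cc2)CC1c1ccc2c(c1)OCCO2` only a limit is recorded in this assay, namely > 200000 nM. Both measured steps that place a substituent on an aromatic carbon of this ring weaken growth inhibition: an at least 3.4-fold higher number from compound 1 to compound 2 (0.54 log units; beyond the scatter) and a 3.4-fold higher number from compound 1 to compound 3 (0.53 log units; beyond the scatter). Compound 4 `Cc1ccc(C2=NN(C(=S)Nc3ccccc3)C(c3ccc4c(c3)OCCO4)C2)cc1C` differs from compound 1 by 3,4-dimethylphenyl in place of phenyl on a carbon with a double bond to nitrogen. As each substitution on this ring among compounds 1, 2 and 3 raised the number, a modest rise in this assay is expected for compound 4 as well. Compound 4 is therefore estimated at 140000 nM in this assay, within 50000 nM to 300000 nM, an expected step of a 2.4-fold higher number from compound 1 to compound 4 (0.39 log units; beyond the scatter).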

Compound 4, concentration for 50% growth inhibition: 144000 nM
The estimate for compound 4 lay 1.0-fold (0.01 log units) below the measured number; the range from low to high includes it.
By their numbers in this assay, from the lowest: compound 1; then compounds 4 and 3 (each within the scatter of the next). At a limit, above all of these: compound 2.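

In this assay, 3,4-dimethylphenyl in place of phenyl gives a 2.5-fold higher number from compound 1 to compound 4 (0.40 log units; beyond the scatter), so a substituent made of carbon alone also raises the number at this position. 3,4-dimethylphenyl in place of 4-(methylsulfanyl)phenyl gives a 1.3-fold lower number from compound 3 to compound 4 (0.13 log units; within the scatter), which leaves these two groups unseparated. 3,4-dimethylphenyl in place of 4-chlorophenyl gives an at least 1.3-fold lower number from compound 2 to compound 4 (0.14 log units; that floor lies within the scatter), which is only a floor and not a measured size. Compound 2 has a limit and not a number: the limit of > 200000 nM in this assay, at which 1 of the 4 values shown sits.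

As far as these compounds go, whether any substituent on this phenyl ring can lower the number remains open, for instance an amine or a carboxylic acid. Also open, from the compounds shown here alone, is whether a single methyl group at the 4-position would match 3,4-dimethylphenyl.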